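A few compounds are considered here, and "the series" means these few. Any claim that something is new, unique, unknown or untested is made for them only; others in the source may bear on it.

Measured so far in an ADME assay on THP-1 cells (Homo sapiens) for cytotoxicity, read by flow cytometry and propidium iodide staining, with a stated time of 72 h; a higher number here means a weaker inhibitor, a lower number a stronger inhibitor:
compound 1, `Nc1ccc2oc(-c3ccc(F)cc3)cc(=O)c2c1`, gives 10000 nM
compound 2, `Nc1ccc2oc(-c3ccc(C(F)(F)F)cc3)cc(=O)c2c1`, gives 1900 nM
compound 3, `COc1c(-c2cccc(F)c2)oc2ccc(N)cc2c1=O`, gives 34000 nM

Compound 2 differs from compound 1 by trifluoromethyl in place of fluoro on an aromatic carbon, a change that brought a 5.3-fold lower number from compound 1 to compound 2 (0.72 log units; beyond the scatter). Compound 3 is built on another core; how the two cores differ is not broken down here, and its number is the highest of the three in this assay. Compound 4, `COc1c(-c2cccc(C(F)(F)F)c2)oc2ccc(N)cc2c1=O`, is not yet measured. It differs from compound 3 by trifluoromethyl in place of fluoro on an aromatic carbon. This is the same kind of change as that between compound 1 and compound 2, though not the same: there the entering group sits para to a large group, here meta to a large group. Compound 4 is expected to give 8000 nM in this assay, because the earlier step was a 5.3-fold lower number from compound 1 to compound 2 (0.72 log units; beyond the scatter). The expected range for compound 4 runs from 3000 nM to 25000 nM. The expected step is a 4.3-fold lower number from compound 3 to compound 4 (0.63 log units; beyond the scatter).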

Compound 4, half-maximal inhibitory concentration: 33000 nM
Compound 4: middle estimate off by 4.1-fold (0.62 log units), on the low side; measured number above the stated range.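

In this assay, the drop seen on the core of compound 1 did not carry over to the core of compound 3, where trifluoromethyl in place of fluoro gave a 1.0-fold lower number from compound 3 to compound 4 (0.01 log units; within the scatter). The two steps for this change do not agree: the same change on two cores in this assay, a 5.3-fold lower number (0.72 log units; beyond the scatter) from compound 1 to compound 2 and a 1.0-fold lower number (0.01 log units; within the scatter) from compound 3 to compound 4, 5.1-fold (0.71 log units) apart, beyond the scatter of two such steps

Among the compounds shown here, this rests on only one pair of compounds per core, and the entering group also sits at a different place on the ring in each pair, so the data do not show whether the core or that place accounts for the gap. Going by these compounds, it remains open whether trifluoromethyl at matching places on the two cores would give matching steps. On these data alone, it also remains open how other groups, such as chloro or a nitrile, would behave at these places.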